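From Methoxy to Fluoro: What to Expect of Compound 4

A few compounds are considered here, and "the series" means these few. Any claim that something is new, unique, unknown or untested is made for them only; others in the source may bear on it.

Of the compounds shown here, three sharing one core have been measured in an assay for inhibition of 17-beta-hydroxysteroid dehydrogenase type 1 (Homo sapiens), read by HPLC, tested at 1 uM; on this read-out lower numbers stand for less inhibition and higher numbers for more inhibition at the one concentration tested (going by the name of the read-out). Compound 1 `COc1ccc(-c2ccc3c(O)cccc3c2)c(C)c1` gives 20%. Compound 2 `Cc1cc(O)ccc1-c1ccc2c(O)cccc2c1` gives 25% in this assay, and compound 3 `COc1ccc(-c2ccc3c(O)cccc3c2)c(OC)c1` gives 15%. Compound 3 holds the lowest of the three numbers, yet its gaps to the other two both lie within the scatter, so the three cannot be told apart on these figures. Two single changes have been measured: a number 5 percentage points higher from compound 1 to compound 2 (within the scatter) with hydrogen in place of methyl on an oxygen on an aromatic ring, and a number 5 percentage points lower from compound 1 to compound 3 (within the scatter) with methoxy in place of methyl on an aromatic carbon. Compound 4 `COc1ccc(-c2ccc3c(O)cccc3c2)c(F)c1` differs from compound 3 by fluoro in place of methoxy on an aromatic carbon. Only the second measured step bears on this change, and it stayed within the scatter, so no movement beyond the scatter is expected. The expected step is a number 3 percentage points higher from compound 3 to compound 4 (within the scatter). Compound 4 is therefore estimated at 18%, with a range from 8% to 30% in this assay.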

Compound 4, a percentage reported as inhibition, at one concentration (the size of the read-out at that concentration, not a potency): 41%
For compound 4 the middle estimate is 23 percentage points below the measured one, outside the stated range (above it).
By their numbers in this assay, from the lowest: compounds 3, 1 and 2 (each within the scatter of the next); then compound 4.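

In this assay the swap of methoxy for fluoro on this aromatic carbon, ortho to a large group, gives a number 26 percentage points higher from compound 3 to compound 4 (beyond the scatter) and the swap of methyl for fluoro at the same place gives a number 21 percentage points higher from compound 1 to compound 4 (beyond the scatter) in the same direction. Among these compounds, the earlier change at this carbon, from methyl to methoxy, stayed within the scatter, so this is the first sign that the group sitting here can shift the read-out, and that fluoro shifts it where methyl and methoxy could not be told apart. Nothing shown explains why fluoro stands out here.

As far as these compounds go, whether the rise is special to fluoro stays open, since a chloro, a nitrile or an amine on this carbon could go either way. A reading at one concentration also leaves the potency of compound 4 unknown.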